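The source may report more compounds than this note shows. Statements on the series, on what has been measured and on what is new or still open speak of the compounds shown alone.

Among the compounds with values here, compound 2 `CS(=O)(=O)OC1=CC(=O)c2ccccc2C1=O` gives the lowest number of the three measured so far: in a functional assay on KB cells (Homo sapiens) for cytotoxicity (a higher number here means a weaker inhibitor, a lower number a stronger inhibitor), compound 2 gives 7180 nM. Its gap to compound 3 `C=CCOc1ccc2c(c1)C(=O)C=CC2=O`, which in this assay gives 10200 nM, lies within the scatter, so the two cannot be told apart. Compound 1 `CC(=O)Oc1ccc2c(c1)C(=O)C=CC2=O` gives 22100 nM in this assay, a gap beyond the scatter. Within the data shown here, the only step measured so far is a 2.2-fold lower number from compound 1 to compound 3 (0.34 log units; beyond the scatter), a change on an oxygen on an aromatic ring.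

Compound 4 `CCCCOC1=CC(=O)c2ccccc2C1=O` differs from compound 2 in one place: butyl in place of methylsulfonyl on an oxygen on an unsaturated carbon. That measured step bears on this only loosely, since it sits on a different oxygen, yet it too swaps a group carrying acceptors for a plain hydrocarbon chain and shifted the number only modestly. Among the measured compounds shown here, no step from compound 2 itself has been measured. The expected change is therefore small, most likely none beyond the scatter: compound 4 is estimated at 8000 nM in this assay, between 3000 nM and 20000 nM, which means an expected step of a 1.1-fold higher number from compound 2 to compound 4 (0.05 log units; within the scatter).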

Compound 4, half-maximal inhibitory concentration: 27000 nM
Estimate against measurement, compound 4: 3.4-fold (0.53 log units) below; measured number above the stated range.
By their numbers in this assay, from the lowest: compounds 2 and 3 (each within the scatter of the next); then compounds 1 and 4 (each within the scatter of the next).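

In this assay, putting butyl in place of methylsulfonyl on an oxygen on an unsaturated carbon gives a 3.8-fold higher number from compound 2 to compound 4 (0.58 log units; beyond the scatter) and so shows that the group held on this oxygen does move the number. Both groups have the same count of heavy atoms and neither has a ring, so heavy-atom count alone does not separate them; the change lies in which atoms are present, with the sulfur, the oxygens and the hydrogen-bond acceptors of methylsulfonyl all gone in butyl. The direction differs from that of a 2.2-fold lower number from compound 1 to compound 3 (0.34 log units; beyond the scatter) on the other oxygen, so across these two pairs, putting a hydrocarbon chain on an oxygen has no single effect.

Nothing measured here explains this difference. From the compounds shown here alone, whether an amine, a carboxylic acid or a shorter or longer chain on this oxygen would sit nearer compound 2 or compound 4 remains open.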